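The source may hold more compounds than are shown below. What is called first, only, known or untested is meant among the compounds shown, and "the series" means these compounds.

Going by the values given here, compound 2 `Cc1c(-c2ccccc2)c(N2CC[C@H](N(C)C)C2)n2nc(C3CC3)nc2c1C#N` has the higher of the two solubility values measured so far. In a physicochemical assay for solubility, at pH 6.8 (on this read-out higher numbers stand for higher solubility and lower numbers for lower solubility), compound 2 gives 57 ug/mL, while compound 1 `CCN(CC)CCNc1c(-c2ccccc2)c(C)c(C#N)c2nc(C(C)(C)C)nn12` gives 2 ug/mL, a much lower number and beyond the scatter; no single-step comparison links these two compounds, so only their values themselves can be compared. Compound 3 `CCc1nc2c(C#N)c(C)c(-c3ccccc3)c(N3CC[C@H](N(C)C)C3)n2n1` has not yet been measured. It differs from compound 2 in one place: ethyl in place of cyclopropyl on an aromatic carbon. Among the compounds with values here, with no measured step of this kind available, the change from compound 2 to compound 3 is expected to give no step beyond the scatter, a 1.0-fold lower number from compound 2 to compound 3 (0.02 log units; within the scatter). Compound 3 is therefore estimated at 55 ug/mL, within 25 ug/mL to 130 ug/mL.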

Compound 3, solubility: 228 ug/mL
Compound 3: middle estimate off by 4.1-fold (0.62 log units), on the low side; measured number above the stated range.
By their numbers in this assay, from the lowest: compound 1; then compound 2; then compound 3.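

Going by these compounds alone, this is the first comparison in the set that differs in one place: on the aromatic carbon of the five-membered ring, ethyl in place of cyclopropyl gives a 4.0-fold higher number from compound 2 to compound 3 (0.60 log units; beyond the scatter) in this assay. The read-out therefore responds to this position, and replacing the three-membered ring with an open ethyl group is enough to move it beyond the scatter. Nothing available here bears on why the step arises.

The compounds shown leave open how methyl, a longer propyl chain or an amine at this carbon would read. They also leave open whether the step would hold with a different side chain elsewhere on the shared core.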